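The compounds below may be only part of what the source reports. "The series", "measured", "known", "first", "only" and "open" are said of these compounds alone.

Series notes: in an ADME assay on microsomes from liver (Homo sapiens) for metabolic stability, read by LC-MS, using NADPH, with a stated time of 10 min, tested at 0.5 uM (a lower number here means that less of the compound is left, a higher number that more of the compound is left), compound 1 (`COC(=O)Nc1cc(-c2ccc(OC[C@@](C)(N)CC(C)C)c(C)c2)ccn1`) gives 98% and compound 2 (`COC(=O)Nc1cc(-c2ccc(OC[C@@](C)(N)CC(C)C)c(C)c2C)ccn1`) gives 93%, so compound 1 stands within the scatter of the only other measured compound. Compound 3 (`COC(=O)Nc1cc(-c2ccc(OC[C@@](C)(N)CC(C)C)c(C3CC3)c2)ccn1`) carries cyclopropyl in place of methyl on an aromatic carbon, ortho to a (2-amino-2,4-dimethylpentyl)oxy group: cyclopropyl in place of methyl on an aromatic carbon. For the measured compounds named here, the only measured step, a number 5 percentage points lower from compound 1 to compound 2 (within the scatter), is methyl in place of hydrogen on an aromatic carbon, not this exchange. It bears only indirectly, and no step beyond the scatter is expected in this assay. Compound 3 is expected at 90%, with an estimated range of 76% to 100%. The expected step is a number 8 percentage points lower from compound 1 to compound 3 (within the scatter).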

Compound 3, percent of the compound remaining: 100%
The estimate for compound 3 lay 10 percentage points below the measured number; the range from low to high includes it.
By their numbers in this assay, from the lowest: compounds 2, 1 and 3 (each within the scatter of the next).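

In this assay, cyclopropyl in place of methyl on the aromatic carbon ortho to the (2-amino-2,4-dimethylpentyl)oxy group gives a number 2 percentage points higher from compound 1 to compound 3 (within the scatter). This position therefore accepts a three-membered carbon ring without a step beyond the scatter, which the methyl-for-hydrogen exchange in compound 2 could not show. No available evidence bears on this result.

Going by these compounds, whether a methoxy group, a trifluoromethyl group or an amine at this position would also stay within the scatter remains open. Compounds 1, 2 and 3 do not yet define any limit to what this position tolerates.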